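A few compounds are considered here, and "the series" means these few. Any claim that something is new, unique, unknown or untested is made for them only; others in the source may bear on it.

Measured so far:
- compound 1 `Cc1nn(C(=O)C2CC2)c(N)c1-c1ccc(Cl)c(Cl)c1`: 24300 nM in an assay on Sf9 cells for inhibition of mitogen-activated protein kinase kinase kinase 14 (Homo sapiens), read by ADP-Glo, with a stated time of 60 min; a lower number here means a stronger inhibitor, a higher number a weaker inhibitor
- compound 2 `Cc1nn(C(=O)C2CCCCC2)c(N)c1-c1ccc(Cl)c(Cl)c1`: 3300 nM in this assay

Of these two numbers, compound 2 holds the lower one; its nearest neighbour is compound 1, and the step between them is a 7.4-fold lower number from compound 1 to compound 2 (0.87 log units; beyond the scatter). Compound 3 `Cc1nn(C(=O)c2cccnc2)c(N)c1-c1ccc(Cl)c(Cl)c1` has not been measured in this assay. It differs from compound 2 at a single place: pyridin-3-yl in place of cyclohexyl on a carbonyl carbon. Within the data shown here, the only measured step that touches this position is a 7.4-fold lower number from compound 1 to compound 2 (0.87 log units; beyond the scatter), a change of one saturated ring for another; no measured pair shows a saturated ring exchanged for an aromatic one at this carbonyl carbon, so that step is a loose guide at best. A step of modest size in either direction, or none beyond the scatter, is what can reasonably be expected. Compound 3 is therefore estimated to give 5000 nM in this assay, with a range of 1500 nM to 16000 nM. This estimate corresponds to an expected step of a 1.5-fold higher number from compound 2 to compound 3 (0.18 log units; within the scatter).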

Compound 3, half-maximal inhibitory concentration: > 100000 nM
Compound 3: a limit, no number; the forecaster's own chance of this, stated with the estimate: 5%; middle value at least 20-fold (1.30 log units) from the limit.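

Compound 3 stands at a limit of this assay, not at a number: the limit of > 100000 nM in this assay, at which 1 of the 3 values shown sits. Among these compounds, at this carbonyl carbon, where the earlier pair had exchanged only one saturated ring for another, pyridin-3-yl in place of cyclohexyl gives an at least 30-fold higher number from compound 2 to compound 3 (1.48 log units; beyond the scatter), although both groups are six-membered rings with the same count of heavy atoms, so ring size alone does not predict the outcome here. Pyridin-3-yl in place of cyclopropyl gives an at least 4.1-fold higher number from compound 1 to compound 3 (0.61 log units; beyond the scatter), which places this aromatic ring behind both saturated rings shown.

The compounds shown leave open whether the loss goes with the aromatic ring as such or with its ring nitrogen, a question that a plain phenyl at the same carbonyl carbon would address. They also leave open how an open alkyl chain or a saturated ring holding an amine would fare there.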